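Methoxy to hydroxy at compound 3

The source may hold more compounds than are shown below. What is called first, only, known or untested is meant among the compounds shown, and "the series" means these compounds.

In a functional assay on MCF7 cells (Homo sapiens) for cytotoxicity, read by MTT assay, with a stated time of 72 h (on this read-out higher numbers stand for weaker inhibition and lower numbers for stronger inhibition), compound 1 `COc1ccc(/C=C2\CCC/C(=C\c3ccc(Cl)cc3)C2=O)cc1OC` gives 6300 nM, compound 2 `COc1ccc(/C=C2\CCC/C(=C\c3ccc(OC)c(OC)c3)C2=O)cc1` gives 7800 nM and compound 3 `COc1ccc(/C=C2\CCC/C(=C\c3ccc(OC)c(OC)c3)C2=O)cc1OC` gives 13500 nM. Among the compounds with values here, the number for compound 3 lies within the scatter of the one for compound 2 and beyond the scatter above the one for compound 1.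

Compound 4 `COc1cc(/C=C2\CCC/C(=C\c3ccc(OC)c(OC)c3)C2=O)ccc1O` differs from compound 3 by hydrogen in place of methyl on an oxygen on an aromatic ring, or methoxy to hydroxy. Within the data shown here, two measured steps bear on this only indirectly. Methoxy in place of chloro gives a 1.2-fold higher number from compound 1 to compound 2 (0.09 log units; within the scatter), and methoxy in place of hydrogen on an aromatic carbon gives a 1.7-fold higher number from compound 2 to compound 3 (0.24 log units; within the scatter). Among the measured compounds shown here, neither step leaves the scatter, and no measured step goes from methoxy to hydroxy, so the direction is poorly supported. The expected change is a 1.5-fold lower number from compound 3 to compound 4 (0.18 log units; within the scatter), a small move to a lower number that is estimated to stay within the scatter. For compound 4 the estimated value is 9000 nM, with an expected range of 3500 nM to 20000 nM.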

Compound 4, half-maximal inhibitory concentration: 7900 nM
The estimate for compound 4 lay 1.1-fold (0.06 log units) above the measured number, within the range that was stated.
By their numbers in this assay, from the lowest: compounds 1, 2, 4 and 3 (each within the scatter of the next, the first and the last beyond it).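

In this assay, within the data shown here, methoxy to hydroxy, the first such change, gives a 1.7-fold lower number from compound 3 to compound 4 (0.23 log units; within the scatter), so removing this methyl does not move the number beyond the scatter. Taking the whole aryl group into account, 4-hydroxy-3-methoxyphenyl in place of 4-methoxyphenyl gives a 1.0-fold higher number from compound 2 to compound 4 (0.01 log units; within the scatter), and in place of 4-chlorophenyl it gives a 1.3-fold higher number from compound 1 to compound 4 (0.10 log units; within the scatter), so a free hydroxy is tolerated at this place without a step leaving the scatter. Nothing available accounts for these readings.

Still open, as far as these compounds go, is how an amine or a longer alkoxy chain at this place would read in this assay. Also open, from the compounds shown here alone, is whether methoxy to hydroxy on the other aromatic ring would stay within the scatter too.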